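From a Six-Membered to a Seven-Membered Ring

This account rests on a few compounds, and the source may have more. Where it says the series, first, only, none or still open, it means among the compounds named here.

Compound 1 `CN1CCN(S(=O)(=O)c2ccc(C3=CC4C(Nc5ccc(OCc6cccc(F)c6)c(Cl)c5)=NC=NC4S3)cc2)CC1` gives > 15 uM in a toxicity assay on HepG2 cells (Homo sapiens) for cytotoxicity, read by MTT assay, with a stated time of 48 h (a higher number here means that more compound is tolerated, a lower number that less compound is tolerated), as its result, which is a limit and not a number. Compound 2 `CN1CCN(S(=O)(=O)c2ccc(-c3ccc4c(Nc5ccc(OCc6cccc(F)c6)c(Cl)c5)cnnc4c3)cc2)CC1` gives > 15 uM in this assay as its result, again a limit. Compound 2 thus stands at the limit of > 15 uM in this assay, at which 2 of the 2 values shown sit, and has no exact value. Going by the values given here, compound 3 `CN1CCCN(S(=O)(=O)c2ccc(-c3ccc4c(Nc5ccc(OCc6cccc(F)c6)c(Cl)c5)cnnc4c3)cc2)CC1` carries 4-methyl-1,4-diazepan-1-yl in place of 4-methylpiperazin-1-yl on a sulfonyl sulfur as its only difference from compound 2. Among the compounds with values here, no measured pair shows this change, so the expected step (a step that the limit leaves unreadable from compound 2 to compound 3) stays within the usual scatter in this assay with no clear direction. For compound 3 the estimated value is 18 uM with an expected range from 9 uM to 40 uM and possibly only a limit again.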

Compound 3, half-maximal toxic concentration: 15 uM
The estimate for compound 3 lay 1.2-fold (0.08 log units) above the measured number; low and high end bracket the measured number.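

In this assay compound 3 gives 15 uM, the first exact number among the compounds shown, so toxicity with 4-methyl-1,4-diazepan-1-yl on the sulfonyl sulfur can be placed on the scale. Compound 2 gives > 15 uM, which is a limit. Putting 4-methyl-1,4-diazepan-1-yl in place of 4-methylpiperazin-1-yl on the sulfonyl sulfur gives a number no higher from compound 2 to compound 3 (the limit leaves the size open). The size of the step therefore cannot be read, and the ring change may matter little or not at all, because compound 2 has no exact value: the limit of > 15 uM in this assay, at which 2 of the 3 values shown sit.

Going by these compounds, whether a morpholin-4-yl or a dimethylamino group on the sulfonyl sulfur would also give an exact number stays open.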